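The source may report more compounds than this note shows. Statements on the series, on what has been measured and on what is new or still open speak of the compounds shown alone.

Measured compounds:
- compound 1 `CCCCCCCn1ccc2cc(/C(C)=C/C(=O)Nc3ccccc3OCCCC(=O)O)ccc21`: 120 nM
- compound 2 `CCC(C)n1ccc2cc(/C(C)=C/C(=O)Nc3ccccc3OCCCC(=O)O)ccc21`: 67 nM
- compound 3 `CCCCC(CCCC)n1ccc2cc(/C(C)=C/C(=O)Nc3ccccc3OCCCC(=O)O)ccc21`: 21 nM

All three were run in an assay on Prostate gland for inhibition of steroid 5-alpha-reductase (Rattus norvegicus); a higher number here means a weaker inhibitor, a lower number a stronger inhibitor. On these numbers compound 2 stands second highest of the three; its nearest neighbour is compound 1, and the step of a 1.8-fold lower number from compound 1 to compound 2 (0.25 log units; within the scatter) lies within the scatter. Its furthest neighbour is compound 3, reached by a 3.2-fold lower number from compound 2 to compound 3 (0.50 log units; beyond the scatter), a step beyond the scatter. The step of a 5.7-fold lower number from compound 1 to compound 3 (0.76 log units; beyond the scatter) points the same way.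

The unmeasured compound 4 `C/C(=C\C(=O)Nc1ccccc1OCCCC(=O)O)c1ccc2c(ccn2C(C(C)C)C(C)C)c1` differs from compound 2 in one place: 1-isopropyl-2-methylpropyl in place of sec-butyl on an aromatic nitrogen. The entering group, 1-isopropyl-2-methylpropyl, is branched at the attaching carbon, as are sec-butyl and 1-butylpentyl, and in heavy-atom count it sits between the two. Going by the values given here, the one step that bears directly on this change is that from compound 2 to compound 3, where a larger branched group on the same nitrogen gave a modest lowering. A lowering of comparable or slightly smaller size is therefore expected in this assay for compound 4. The step from compound 2 to compound 4 is estimated at a 2.2-fold lower number from compound 2 to compound 4 (0.35 log units; beyond the scatter). Compound 4 is expected to give 30 nM, within a range from 12 nM to 80 nM.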

Compound 4, half-maximal inhibitory concentration: 14 nM
For compound 4 the middle estimate is 2.1-fold (0.33 log units) above the measured one; the measured number falls inside the stated range.
By their numbers in this assay, from the lowest: compounds 4 and 3 (each within the scatter of the next); then compounds 2 and 1 (each within the scatter of the next).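

In this assay, 1-isopropyl-2-methylpropyl on the aromatic nitrogen gives a 4.8-fold lower number from compound 2 to compound 4 (0.68 log units; beyond the scatter), and an 8.6-fold lower number from compound 1 to compound 4 (0.93 log units; beyond the scatter), so a second group branched at the attaching carbon and larger than sec-butyl also stands clear of both sec-butyl and heptyl. Against 1-butylpentyl the change gives a 1.5-fold lower number from compound 3 to compound 4 (0.18 log units; within the scatter), so isopropyl and butyl branches on the attaching carbon cannot be told apart at this position in this assay. No evidence at hand accounts for these differences.

Still open, going by these compounds, is how a ring on the same nitrogen, such as cyclohexyl, or a longer branched chain, such as 1-pentylhexyl, would compare with these two groups. All the compounds shown keep the same carboxylic acid chain, so whether these steps hold with a tetrazole in place of the carboxylic acid also remains open.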